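The source may report more compounds than this note shows. Statements on the series, on what has been measured and on what is new or still open speak of the compounds shown alone.

Measured in a functional assay on Ehrlich cells (Mus musculus) for cytotoxicity, read by LDH release, with a stated time of 48 h; on this read-out lower numbers stand for stronger inhibition and higher numbers for weaker inhibition:

- compound 1 `Cc1ccc(C(=O)c2ccc(OCC(=O)Nc3nc(-c4ccccc4)cs3)c(C)c2)cc1` gives 30500 nM
- compound 2 `COc1ccc(-c2csc(NC(=O)COc3ccc(C(=O)c4ccc(C)cc4)cc3C)n2)cc1` gives 20900 nM
- compound 3 `Cc1cc(C(=O)c2ccc(F)cc2)ccc1OCC(=O)Nc1nc(-c2ccccc2)cs1` gives 38600 nM

Compound 2 stands together with the other two compounds, since all three values lie within the usual scatter of each other. Compound 4 `COc1ccc(-c2csc(NC(=O)COc3ccc(C(=O)c4cccc(Br)c4)cc3C)n2)cc1` keeps the rest of compound 2 and differs by 3-bromophenyl in place of 4-methylphenyl on a carbonyl carbon.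

Two measured steps offer some guidance. The closer one is a 1.3-fold higher number from compound 1 to compound 3 (0.10 log units; within the scatter), where fluoro replaces the methyl of the same 4-methylphenyl group. The other, a 1.5-fold lower number from compound 1 to compound 2 (0.16 log units; within the scatter), adds methoxy elsewhere in the molecule and is the change that compound 2 already carries. Within the data shown here, neither step goes beyond the scatter, but no measured compound carries bromine, so this evidence is only indirect. The expected result is therefore no shift beyond the scatter, with an estimated 1.1-fold higher number from compound 2 to compound 4 (0.04 log units; within the scatter). For compound 4 the estimated value is 23000 nM, with an expected range from 10000 nM to 50000 nM.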

Compound 4, half-maximal inhibitory concentration: 40600 nM
Beside the measured number, compound 4's estimate is 1.8-fold (0.25 log units) below it; low and high end bracket the measured number.
By their numbers in this assay, from the lowest: compounds 2, 1, 3 and 4 (each within the scatter of the next).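

In this assay, putting 3-bromophenyl in place of 4-methylphenyl on the carbonyl carbon gives a 1.9-fold higher number from compound 2 to compound 4 (0.29 log units; within the scatter). Among these compounds, until now, the only change seen on this ring was fluoro in place of methyl, so this result extends the picture: a larger change, with bromine as the substituent and a different number in the group's name, still does not move the value beyond the scatter. No supporting measurement bears on this result.

Because the substituent and its place on the ring change together in this one step, the compounds shown cannot separate the contribution of bromine from that of its place. They also leave open whether this ring would tolerate a very different group, such as an amine, a carboxylic acid or a longer chain.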